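Removing One Fluoro From the Weakest Benzoyl Analogue

This account rests on a few compounds, and the source may have more. Where it says the series, first, only, none or still open, it means among the compounds named here.

Measured so far in a functional assay on A549 cells (Homo sapiens) for inhibition, read by MTT assay, with a stated time of 72 h; a higher number here means a weaker inhibitor, a lower number a stronger inhibitor:
- compound 1 `CN(C(=O)NC(=O)c1ccc(F)c(F)c1)c1nc(C(F)(F)F)c(C(=O)N/N=C/c2ccc(C(F)(F)F)cc2)s1` gives 6.07 ug/mL
- compound 2 `CN(C(=O)NC(=O)c1cccc(C(F)(F)F)c1)c1nc(C(F)(F)F)c(C(=O)N/N=C/c2ccc(C(F)(F)F)cc2)s1` gives 6.2 ug/mL
- compound 3 `CN(C(=O)NC(=O)c1c(F)cccc1F)c1nc(C(F)(F)F)c(C(=O)N/N=C/c2ccc(C(F)(F)F)cc2)s1` gives 40.1 ug/mL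

All three share one core and differ only in the ring attached to the carbonyl carbon. Compound 3 stands highest of the three, the weakest inhibitor here, and its distance from the other two is beyond the scatter: a 6.6-fold higher number from compound 1 to compound 3 (0.82 log units; beyond the scatter) and a 6.5-fold higher number from compound 2 to compound 3 (0.81 log units; beyond the scatter).

Compound 4 `CN(C(=O)NC(=O)c1ccccc1F)c1nc(C(F)(F)F)c(C(=O)N/N=C/c2ccc(C(F)(F)F)cc2)s1` is compound 3 with hydrogen in place of fluoro on an aromatic carbon. Among the measured compounds shown here, no measured step removes a single fluoro, so the two steps above are the only guide; both say the 2,6-difluorophenyl ring is the weakest of the rings tried. A partial return toward compound 1 and compound 2 is therefore expected, a 2.7-fold lower number from compound 3 to compound 4 (0.43 log units; beyond the scatter). Compound 4 is estimated at 15 ug/mL, within a range from 5 ug/mL to 45 ug/mL.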

Compound 4, half-maximal inhibitory concentration: 5.68 ug/mL
Compound 4: the middle estimate sits 2.6-fold (0.42 log units) above what was measured; measured number inside the range.
By their numbers in this assay, from the lowest: compounds 4, 1 and 2 (each within the scatter of the next); then compound 3.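

In this assay, removing one fluoro from the 2,6-difluorophenyl ring gives a 7.1-fold lower number from compound 3 to compound 4 (0.85 log units; beyond the scatter), so the high number of compound 3 depends on that second fluoro and not on the presence of one fluoro alone. The 2-fluorophenyl ring also matches the other two rings, with a 1.1-fold lower number from compound 2 to compound 4 (0.04 log units; within the scatter) and a 1.1-fold lower number from compound 1 to compound 4 (0.03 log units; within the scatter). No measured evidence accounts for this effect of the second fluoro. From the compounds shown here alone, it remains open whether a chloro, methyl or methoxy group in place of the remaining fluoro would match compound 4, and how a plain phenyl ring would compare.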